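A few compounds are considered here, and "the series" means these few. Any claim that something is new, unique, unknown or untested is made for them only; others in the source may bear on it.

Measured so far:
compound 1, `O=C(Nc1cccc(-n2cc(-c3ccncc3)c(-c3cc(O)cc(Cl)c3)n2)c1)Nc1ccc(Cl)c(Cl)c1`: 95%
compound 2, `COc1cc(Cl)cc(-c2nn(-c3cccc(NC(=O)Nc4ccc(Cl)c(C(F)(F)F)c4)c3)cc2-c2ccncc2)c1`: 96%

Both numbers come from a functional assay on SK-MEL-5 cells (Homo sapiens) for inhibition, read by sulforhodamine B assay, with a stated time of 48 h, tested at 0.01 uM; on this read-out higher numbers stand for a weaker effect at the one concentration tested and lower numbers for a stronger effect. Compound 2 stands alongside compound 1, the two values within the scatter of each other, so no ordering between them is claimed; both sit near the top of the activity read-out at the single concentration tested. Compound 3, `COc1cc(Cl)cc(-c2nn(-c3cccc(NC(=O)Nc4ccc(Cl)c(Cl)c4)c3)cc2-c2ccncc2)c1`, is not yet measured. It differs from compound 2 by chloro in place of trifluoromethyl on an aromatic carbon. Among the compounds with values here, no step between measured compounds bears on this change, so the expected step is none beyond the scatter, a number 1 percentage points lower from compound 2 to compound 3 (within the scatter). Compound 3 is estimated at 95%, with a range from 85% to 102%.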

Compound 3, a percentage reported as activity, at one concentration (the size of the read-out at that concentration, not a potency): 95%
Compound 3: the middle estimate sits on the measured number at the digits printed, within the range that was stated.
By their numbers in this assay, from the lowest: compounds 1, 3 and 2 (each within the scatter of the next).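

In this assay, chloro in place of trifluoromethyl on this aromatic carbon, ortho to a chloro group, reads a number 1 percentage points lower from compound 2 to compound 3 (within the scatter), a single-place comparison that compounds 1 and 2 alone could not offer. Methyl in place of hydrogen on the oxygen on an aromatic ring reads no change at the digits printed from compound 1 to compound 3 (within the scatter), so neither change separates the compounds at this one concentration. No measurement at hand explains either result.

On these data alone, whether an amine, a carboxylic acid or a longer chain on this aromatic carbon would shift the read-out remains open. As far as these compounds go, how the three compounds compare at other concentrations also stays open.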